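Notes on a small series: methylamino in place of methoxy

The source may report more compounds than this note shows. Statements on the series, on what has been measured and on what is new or still open speak of the compounds shown alone.

Measured in an assay on HEK293 cells for displacement of a labelled ligand from 5-hydroxytryptamine receptor 7 (Rattus norvegicus), read by radioligand binding; a lower number here means a stronger inhibitor, a higher number a weaker inhibitor:
compound 1 `CCn1nc2c(c1-c1ccccc1)CCNCC2` gives 140 nM
compound 2 `CC(C)n1nc2c(c1-c1ccccc1)CCNCC2` gives 28 nM
compound 3 `COc1ccc(-c2c3c(nn2C(C)C)CCNCC3)cc1` gives 18 nM

Compound 3 carries the lowest of the three numbers in this assay, but its gap to compound 2 lies within the scatter, so the two cannot be ordered; only compound 1 stands clearly apart, beyond the scatter. Within the data shown here, the step of a 5.0-fold lower number from compound 1 to compound 2 (0.70 log units; beyond the scatter) is the one change of size seen so far. The step of a 1.6-fold lower number from compound 2 to compound 3 (0.19 log units; within the scatter), which installs the methoxy, stays within the scatter.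

Compound 4 `CNc1ccc(-c2c3c(nn2C(C)C)CCNCC3)cc1` differs from compound 3 by methylamino in place of methoxy on an aromatic carbon. Among the measured compounds shown here, no measured step swaps one small group for another at this position; the nearest precedent is the step from compound 2 to compound 3, where adding the methoxy at the same place moved the number within the scatter only. On that basis a step of a 1.4-fold higher number from compound 3 to compound 4 (0.14 log units; within the scatter) is expected, that is, no change beyond the scatter. Compound 4 is accordingly estimated at 25 nM in this assay, with a range from 8 nM to 80 nM.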

Compound 4, inhibition constant: 40 nM
Beside the measured number, compound 4's estimate is 1.6-fold (0.20 log units) below it; the measured number falls inside the stated range.
By their numbers in this assay, from the lowest: compounds 3, 2 and 4 (each within the scatter of the next, the first and the last beyond it); then compound 1.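

In this assay, among these compounds, the step of a 2.2-fold higher number from compound 3 to compound 4 (0.35 log units; beyond the scatter) is the first at this position, para to a large group, to pass beyond the scatter, though only modestly: exchanging methoxy for methylamino keeps the heavy-atom count and adds one hydrogen-bond donor, yet it still registers. The step of a 1.4-fold higher number from compound 2 to compound 4 (0.15 log units; within the scatter) leaves compound 4 within the scatter of compound 2, as compound 3 also is, so the two groups separate from each other but neither separates from hydrogen. Nothing available accounts for the difference between the two groups.

On these data alone, whether the step follows the hydrogen-bond donor that enters with methylamino stays open; a dimethylamino or a hydroxy group at this place would bear on that. Also open, as far as these compounds go, is whether the exchange gives a step of similar size with the ethyl group of compound 1 on the core.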